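This account rests on a few compounds, and the source may have more. Where it says the series, first, only, none or still open, it means among the compounds named here.

Measured so far:
- compound 1 `COc1ccc(C2CC(c3ccc(OC)c(OC)c3)=NN2C(=O)CBr)c(OC)c1` gives 53%
- compound 2 `COc1ccc(C2=NN(C(=O)C(C)O[N+](=O)[O-])C(c3ccco3)C2)cc1OC` gives 35%

Both compounds were tested in a functional assay on the whole organism (strain albino) for inhibition, with Rattus norvegicus as the target, read by paw edema, with stated times of 30 min and 1 h, at a dose of 100 mg/kg by the oral route; a lower number here means less inhibition, a higher number more inhibition at the dose given (going by the name of the read-out). Of the two numbers, compound 2 holds the lower one, and compound 1 sits higher by a gap that lies beyond the usual scatter of this kind of measurement, so the two compounds are genuinely told apart here. Among the compounds with values here, no single-change step between measured compounds is available, so the contribution of any one group cannot be read off directly.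

Compound 3 `COc1ccc(C2CC(c3ccc(OC)c(OC)c3)=NN2C(=O)C(C)O[N+](=O)[O-])c(OC)c1` has not yet been measured. It differs from compound 2 in one place: 2,4-dimethoxyphenyl in place of furan-2-yl on a saturated ring carbon. The 2,4-dimethoxyphenyl group that enters is the same group that compound 1 carries on its saturated ring carbon, though compound 1 differs from compound 3 in another part of the molecule, so compound 1 is only a partial guide.

For this assay a rise from compound 2 to compound 3 of a number 11 percentage points higher from compound 2 to compound 3 (beyond the scatter) is expected, leaning on the higher reading of compound 1 at 53%. Compound 3 is therefore estimated at 46%, within a range from 32% to 60%.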

Compound 3, a percentage reported as inhibition, in the whole organism at one dose (the size of the read-out at that dose, not a potency): 44%
Estimate against measurement, compound 3: 2 percentage points above, and the stated range covers the measured number.
By their numbers in this assay, from the lowest: compounds 2, 3 and 1 (each within the scatter of the next, the first and the last beyond it).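

In this assay, placing 2,4-dimethoxyphenyl instead of furan-2-yl on the saturated ring carbon gives a number 9 percentage points higher from compound 2 to compound 3 (within the scatter), so this assay does not separate the five-membered aromatic ring with one oxygen from the larger six-membered aromatic ring of carbon only at this position. On the carbonyl carbon, 1-(nitrooxy)ethyl in place of bromomethyl gives a number 9 percentage points lower from compound 1 to compound 3 (within the scatter), so the two side chains cannot be told apart here either, and neither single change is shown to matter on its own. No measurement is available that could explain these two results.

The compounds shown leave open whether a group of a different kind on the saturated ring carbon, such as a plain methyl or a phenyl ring carrying a carboxylic acid, would shift the reading beyond the scatter, and the same question holds for a longer chain or an amine in place of the side chain on the carbonyl carbon. As far as these compounds go, each reading also comes from a single oral dose, so it remains open whether these compounds would separate at other doses.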